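The source may report more compounds than this note shows. Statements on the series, on what has been measured and on what is new or still open speak of the compounds shown alone.

Measured so far, in a functional assay on HeLa cells (Homo sapiens) for inhibition, read by MTT assay, with a stated time of 72 h; a lower number here means a stronger inhibitor, a higher number a weaker inhibitor:

Compound 1 `Cc1noc(C)c1-c1cnc(N)c(Oc2ccc(C(=O)Nc3ccccc3)cc2)n1` gives 10500 nM.
Compound 2 `Cc1noc(C)c1-c1cnc(N)c(Oc2ccc(C(=O)Nc3ccccc3Cl)cc2)n1` gives 81300 nM.
Compound 3 `Cn1cc(-c2cnc(N)c(Oc3ccc(C(=O)Nc4ccccc4)cc3)n2)cn1` gives 12300 nM.

Compound 3 stands second highest of these three numbers. Its nearest neighbour is compound 1, whose number is lower only within the scatter, as the comparison a 1.2-fold higher number from compound 1 to compound 3 (0.07 log units; within the scatter) shows. The furthest is compound 2, whose number is higher by more than the scatter.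

Compound 4 `Cn1cc(-c2cnc(N)c(Oc3ccc(C(=O)Nc4ccccc4Cl)cc3)n2)cn1` is not yet measured. It differs from compound 3 by a single change: chloro in place of hydrogen on an aromatic carbon.

Among the measured compounds shown here, one measured step bears directly on this change, since compounds 1 and 2 differ in exactly the same way: a 7.7-fold higher number from compound 1 to compound 2 (0.89 log units; beyond the scatter). That step was modest but beyond the scatter, and it ran toward a weaker inhibitor. Nothing else among the measured compounds speaks against carrying it over, so the step of a 7.3-fold higher number from compound 3 to compound 4 (0.86 log units; beyond the scatter) is expected, toward a higher number in this assay.

Compound 4 is therefore estimated at 90000 nM, with a range from 30000 nM to 250000 nM.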

Compound 4, half-maximal inhibitory concentration: 73000 nM
For compound 4 the middle estimate is 1.2-fold (0.09 log units) above the measured one; low and high end bracket the measured number.
By their numbers in this assay, from the lowest: compounds 1 and 3 (each within the scatter of the next); then compounds 4 and 2 (each within the scatter of the next).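

In this assay, the change from phenylcarbamoyl to (2-chlorophenyl)carbamoyl also costs activity on the second core (a 5.9-fold higher number from compound 3 to compound 4 (0.77 log units; beyond the scatter)), so the loss is no longer tied to the 3,5-dimethyl-1,2-oxazol-4-yl compounds, and its size holds across both cores: the same change on two cores in this assay, a 7.7-fold higher number (0.89 log units; beyond the scatter) from compound 1 to compound 2 and a 5.9-fold higher number (0.77 log units; beyond the scatter) from compound 3 to compound 4, 1.3-fold (0.12 log units) apart, within the scatter of two such steps. Exchanging 3,5-dimethyl-1,2-oxazol-4-yl for 1-methyl-1H-pyrazol-4-yl still makes no difference beyond the scatter when the chloro is present (a 1.1-fold lower number from compound 2 to compound 4 (0.05 log units; within the scatter)), so across these four compounds, the effect of one change does not depend on the other: the same change on two cores in this assay, a 1.2-fold higher number (0.07 log units; within the scatter) from compound 1 to compound 3 and a 1.1-fold lower number (0.05 log units; within the scatter) from compound 2 to compound 4, 1.3-fold (0.12 log units) apart, within the scatter of two such steps.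

Going by these compounds, whether the loss is specific to chloro remains open, since fluoro, methyl or methoxy at this same place could give a smaller step or a larger one. Also open, on these data alone, is whether a group such as an amine or a carboxylic acid on this ring could give a lower number than the unsubstituted compounds.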